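This account rests on a few compounds, and the source may have more. Where it says the series, first, only, none or still open, it means among the compounds named here.

Compound 1 `COc1cc(/C=N\NC(=O)c2cn(C3CC3)c3c(OC)c(N4CCN(C)CC4)c(F)cc3c2=O)cc(OC)c1OC` gives 8.5 ug/mL
Compound 2 `COc1ccc(OC)c(/C=N\NC(=O)c2cn(C3CC3)c3c(OC)c(N4CCN(C)CC4)c(F)cc3c2=O)c1` gives 3 ug/mL

In a functional assay on PC-3 cells (Homo sapiens) for inhibition, read by MTT assay (a lower number here means a stronger inhibitor, a higher number a weaker inhibitor), compound 1 holds the higher of the two numbers at 8.5 ug/mL and is the weaker inhibitor of the pair. Compound 3 `COc1c(N2CCN(C)CC2)c(F)cc2c(=O)c(C(=O)N/N=C\c3ccccc3)cn(C3CC3)c12` carries phenyl in place of 3,4,5-trimethoxyphenyl on a carbon with a double bond to nitrogen and is otherwise unchanged. Going by the values given here, the only measured step at this place is a 2.8-fold lower number from compound 1 to compound 2 (0.45 log units; beyond the scatter) with 2,5-dimethoxyphenyl entering, so a modest step toward a lower number is expected, on this single precedent. The expected change is a 2.4-fold lower number from compound 1 to compound 3 (0.39 log units; beyond the scatter) in this assay and rests on that one step alone. For compound 3 the estimate is 3.5 ug/mL (expected range 1.2 ug/mL to 10 ug/mL).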

Compound 3, half-maximal inhibitory concentration: 16.3 ug/mL
Beside the measured number, compound 3's estimate is 4.7-fold (0.67 log units) below it, outside the stated range (above it).
By their numbers in this assay, from the lowest: compound 2; then compounds 1 and 3 (each within the scatter of the next).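

In this assay the step of a 1.9-fold higher number from compound 1 to compound 3 (0.28 log units; within the scatter) does not separate phenyl from 3,4,5-trimethoxyphenyl on a carbon with a double bond to nitrogen, whereas a 5.4-fold higher number from compound 2 to compound 3 (0.74 log units; beyond the scatter) sets 2,5-dimethoxyphenyl apart from phenyl. Among these three compounds, carrying methoxy groups does not by itself go with a lower number, and compound 1 goes against that reading. No available evidence accounts for this difference. From the compounds shown here alone, whether a phenyl bearing a single methoxy, a hydroxyl or a dimethylamino group would sit with compound 2 or with compound 3 remains open.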